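The compounds below may be only part of what the source reports. "The series", "measured", "known", "first", "only" and "open" are said of these compounds alone.

Compound 1 `N#Cc1c(N)nc(SCc2cccc(C(N)=O)c2)c(C#N)c1-c1ccc(OCC2CC2)cc1` gives 12.7 nM in a functional assay on CHO cells for agonist activity at adenosine receptor A2b (Homo sapiens), read by AlphaScreen and cAMP accumulation; on this read-out higher numbers stand for an effect only at larger amounts of compound and lower numbers for an effect already at smaller amounts.
Compound 2 `N#Cc1c(N)nc(SCc2ncn[nH]2)c(C#N)c1-c1ccc(OCC2CC2)cc1` gives 51 nM in this assay.
Compound 3 `N#Cc1c(N)nc(SCC(=O)NCO)c(C#N)c1-c1ccc(OCC2CC2)cc1` gives 182 nM in this assay.

Compound 3 carries the highest number of the three: a 14-fold higher number from compound 1 to compound 3 (1.16 log units; beyond the scatter) and a 3.6-fold higher number from compound 2 to compound 3 (0.55 log units; beyond the scatter), both beyond the scatter. Compound 4 `CNC(=O)CSc1nc(N)c(C#N)c(-c2ccc(OCC3CC3)cc2)c1C#N` differs from compound 3 only in that (hydrogen in place of hydroxy on a saturated chain carbon bound to an amide-type nitrogen). Among the measured compounds shown here, none of the measured steps touches this position; each of them, like a 4.0-fold higher number from compound 1 to compound 2 (0.60 log units; beyond the scatter), exchanges the whole group on the saturated chain carbon bound to a sulfur. For the measured compounds named here, no measured step therefore bears on the change to compound 4, and removal of the hydroxy group is expected to move this assay by no more than the scatter, in no fixed direction. The step is estimated as a 1.1-fold lower number from compound 3 to compound 4 (0.06 log units; within the scatter). Compound 4 is expected at 160 nM, within 60 nM to 420 nM.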

Compound 4, half-maximal effective concentration: 94 nM
Compound 4: middle estimate off by 1.7-fold (0.23 log units), on the high side; the range from low to high includes it.
By their numbers in this assay, from the lowest: compound 1; then compounds 2, 4 and 3 (each within the scatter of the next, the first and the last beyond it).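

At the saturated chain carbon bound to an amide-type nitrogen, hydroxy and hydrogen are not separated in this assay: a 1.9-fold lower number from compound 3 to compound 4 (0.29 log units; within the scatter). The methylcarbamoyl group is likewise not separated from 1H-1,2,4-triazol-5-yl, with a 1.8-fold higher number from compound 2 to compound 4 (0.27 log units; within the scatter), while 3-carbamoylphenyl remains clearly apart, with a 7.4-fold higher number from compound 1 to compound 4 (0.87 log units; beyond the scatter). Nothing available gives a reason for any of these steps.

Still open, as far as these compounds go, is whether an amine or methoxy on this carbon, or a longer chain in place of methyl, would move the number beyond the scatter.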